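Swapping a Thiophene for a Bromophenyl at the Same Position

The source may hold more compounds than are shown below. What is called first, only, known or untested is meant among the compounds shown, and "the series" means these compounds.

Of the compounds shown here, two built on one shared core have been tested in a functional assay on MDA-MB-468 cells (Homo sapiens) for inhibition, read by sulforhodamine B assay, with a stated time of 48 h, tested at 10 uM; on this read-out higher numbers stand for more inhibition at the one concentration tested (going by the name of the read-out) and lower numbers for less inhibition. Compound 1 `Brc1cn2ccnc2c(-c2ccc3ncn(C4CCCCC4)c3c2)n1`, which carries a bromo group on the core, gives 44.4% in this assay. Compound 2 `c1cn2cc(-c3ccsc3)nc(-c3ccc4ncn(C5CCCCC5)c4c3)c2n1`, in which a thiophen-3-yl group takes the place of that bromo, gives 21.8% in this assay. Between them the change is a number 22.6 percentage points lower from compound 1 to compound 2 (beyond the scatter), so compound 2 stands as the lower of the two numbers, with compound 1 lying clearly above it.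

Compound 3 `Brc1ccc(-c2cn3ccnc3c(-c3ccc4ncn(C5CCCCC5)c4c3)n2)cc1` has not yet been measured. It differs from compound 2 by 4-bromophenyl in place of thiophen-3-yl on an aromatic carbon. Going by the values given here, the only step measured so far, from a small bromo group to a thiophene ring at this position, lowered inhibition beyond the scatter. Compound 3 keeps an aromatic ring at that spot, so the outcome is expected to sit nearer to compound 2 than to compound 1. In this assay, compound 3 is therefore estimated to give 28%, within a range from 5% to 55%, which corresponds to an expected step of a number 6.2 percentage points higher from compound 2 to compound 3 (within the scatter).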

Compound 3, a percentage reported as inhibition, at one concentration (the size of the read-out at that concentration, not a potency): 33.7%
Compound 3: the middle estimate sits 5.7 percentage points below what was measured; measured number inside the range.
By their numbers in this assay, from the lowest: compound 2; then compound 3; then compound 1.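

In this assay the identity of the ring matters: the step is a number 11.9 percentage points higher from compound 2 to compound 3 (beyond the scatter) when 4-bromophenyl takes the place of thiophen-3-yl, so two aromatic rings on this carbon need not give the same number. The bromo group of compound 1 still gives the highest number of the three, the step being a number 10.7 percentage points lower from compound 1 to compound 3 (beyond the scatter) when 4-bromophenyl replaces it, so among these compounds the six-membered ring recovers only part of what the thiophene step lost. Nothing available here explains this order of the three compounds.

The compounds shown cannot separate the effect of the six-membered ring from that of the bromine it carries, and a plain phenyl group on this carbon would tell those two apart. They also leave open how a group that is not an aromatic ring, such as an amine or a short alkyl chain, would compare with bromo at this position, and a reading at one concentration gives no measure of potency for any of them.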